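Para-fluoro on the benzamide of compound 2

The source may hold more compounds than are shown below. What is called first, only, known or untested is meant among the compounds shown, and "the series" means these compounds.

Of the compounds shown here, two have been measured in a functional assay on MDA-MB-468 cells (Homo sapiens) for inhibition; a higher number here means a weaker inhibitor of growth, a lower number a stronger inhibitor of growth. Compound 1, `COc1cccc(-c2nn(-c3ccccc3)cc2-c2ccnc(NCCNC(=O)Nc3cccc(C(F)(F)F)c3)c2)c1`, a urea-linked analogue carrying a methoxy group on the aryl ring of the shared core, gives 3500 nM. Compound 2, `O=C(NCCCNc1cc(-c2cn(-c3ccccc3)nc2-c2cccc(O)c2)ccn1)c1ccccc1`, with a phenol on that ring and a benzamide on a three-carbon chain, gives 3360 nM in this assay. The two numbers sit within the scatter of each other, so compound 2 serves here only as the reference point for the next change, not as a stronger or weaker member of the pair.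

Compound 3, `O=C(NCCCNc1cc(-c2cn(-c3ccccc3)nc2-c2cccc(O)c2)ccn1)c1ccc(F)cc1`, differs from compound 2 by a single change: fluoro in place of hydrogen on an aromatic carbon. Among the measured compounds shown here, no measured pair shows this change, so its effect on this assay is unknown from the data.

With nothing in the series to suggest otherwise, compound 3 is expected to land close to compound 2, with a step of a 1.1-fold lower number from compound 2 to compound 3 (0.05 log units; within the scatter) that stays within the scatter. The estimate for compound 3 in this assay is 3000 nM, in a range from 1200 nM to 7500 nM.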

Compound 3, concentration for total growth inhibition: 3430 nM
Beside the measured number, compound 3's estimate is 1.1-fold (0.06 log units) below it, and the stated range covers the measured number.
By their numbers in this assay, from the lowest: compounds 2, 3 and 1 (each within the scatter of the next).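

In this assay, fluoro in place of hydrogen on an aromatic carbon, para to a large group, gives a 1.0-fold higher number from compound 2 to compound 3 (0.01 log units; within the scatter), so compound 2 and compound 3 cannot be told apart at this position. Among the compounds shown here, this is the first step that can be read at a single place, since compound 1 and compound 2 differ in more than one place and their closeness says nothing about any one part of the structure. Going from benzoyl to (4-fluorophenyl)carbonyl therefore leaves the read-out indistinguishable here, and the data available offer no independent measurement that bears on this result.

As far as these compounds go, one small atom at one place is a narrow test, so it remains open whether a larger or differently charged group in the same place, such as a chloro, a nitrile, an amine or a carboxylic acid, would also leave the number within the scatter. The same applies to a longer chain in the linker, and to replacing the phenol of compound 2 with a methoxy group while everything else stays the same.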